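The source may hold more compounds than are shown below. What is called first, only, known or untested is meant among the compounds shown, and "the series" means these compounds.

Compound 1 `CC1(C)CC(NC(=O)Nc2ccccc2Cl)c2cc(Cl)ccc2O1` was tested in a functional assay on T98G cells (Homo sapiens) for inhibition, read by MTT assay, with a stated time of 72 h (on this read-out higher numbers stand for weaker inhibition and lower numbers for stronger inhibition), where compound 1 gives 20000 nM. Among the measured compounds shown here, of the two numbers measured so far this is the higher one; its only neighbour is compound 2 `CC1(C)CC(NC(=O)Nc2ccccc2Cl)c2cc(Br)ccc2O1`, which in this assay gives 11000 nM, and the step of a 1.8-fold lower number from compound 1 to compound 2 (0.26 log units; within the scatter) leaves the two within the scatter. The next compound, compound 3 `CC1(C)CC(NC(=O)Nc2ccc(Cl)cc2)c2cc(Cl)ccc2O1`, differs from compound 1 by 4-chlorophenyl in place of 2-chlorophenyl on an amide-type nitrogen. For the measured compounds named here, no measured step bears on this change: the single step recorded so far concerns a halogen on the shared core, not the phenyl group on the urea nitrogen, and is itself within the scatter. Going by the values given here, with no comparable precedent, no step beyond the scatter is expected in this assay in either direction. Compound 3 is therefore expected to give 20000 nM, with a range from 6000 nM to 60000 nM, which corresponds to an expected step of no change at the digits printed from compound 1 to compound 3 (within the scatter).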

Compound 3, half-maximal inhibitory concentration: 33000 nM
Compound 3: middle estimate off by 1.7-fold (0.22 log units), on the low side; the range from low to high includes it.
By their numbers in this assay, from the lowest: compounds 2, 1 and 3 (each within the scatter of the next, the first and the last beyond it).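

In this assay, among the compounds shown here, 4-chlorophenyl in place of 2-chlorophenyl on an amide-type nitrogen gives a 1.7-fold higher number from compound 1 to compound 3 (0.22 log units; within the scatter), the first measured step at this position, which the earlier pair left untouched. This step stays within the scatter, so the two chlorophenyl groups cannot be told apart here, just as the halogen change on the shared core could not be, with a 1.8-fold lower number from compound 1 to compound 2 (0.26 log units; within the scatter). No data shown here bear on the reason for this result.

The compounds shown leave open whether 3-chlorophenyl at this nitrogen would read like compound 1 and compound 3, or whether an unsubstituted phenyl would. They also leave open whether a phenyl group carrying a methoxy group or a carboxylic acid would produce a step beyond the scatter.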